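An Amino-to-Methoxy Change on the Shared Core

The source may hold more compounds than are shown below. What is called first, only, known or untested is meant among the compounds shown, and "the series" means these compounds.

Compound 1 `Nc1nc(N)c2c(-c3cc4ccccc4o3)cn([C@@H]3O[C@H](CO)[C@@H](O)[C@H]3O)c2n1` gives only a limit, > 20000 nM.
Compound 2 `Nc1nc(N)c2c(-c3ccoc3)cn([C@@H]3O[C@H](CO)[C@@H](O)[C@H]3O)c2n1` gives only a limit, > 20000 nM.
Compound 3 `Nc1nc(N)c2c(-c3ccco3)cn([C@@H]3O[C@H](CO)[C@@H](O)[C@H]3O)c2n1` gives only a limit, > 20000 nM.

These three values come from a functional assay on HCT-116 cells (Homo sapiens), read by MTT assay, with a stated time of 72 h (on this read-out higher numbers stand for weaker inhibition and lower numbers for stronger inhibition), and none of them is a number: each is the limit of > 20000 nM in this assay, at which 3 of the 3 values shown sit. Compound 2 therefore stands at a limit, with no number of its own. The steps a step that the two limits leave unreadable from compound 1 to compound 2, a step that the two limits leave unreadable from compound 1 to compound 3 and a step that the two limits leave unreadable from compound 2 to compound 3 cannot be sized. Compound 4 `COc1nc(N)nc2c1c(-c1ccoc1)cn2[C@@H]1O[C@H](CO)[C@@H](O)[C@H]1O` differs from compound 2 by methoxy in place of amino on an aromatic carbon. Within the data shown here, no measured step bears on this kind of exchange, and the measured steps themselves have no readable size, so no direction can be drawn from them. Compound 4 is expected to sit at the limit again, giving 30000 nM with a range from 10000 nM to 100000 nM. The expected step that the limit leaves unreadable from compound 2 to compound 4 is thus not expected to be readable either.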

Compound 4, half-maximal inhibitory concentration: > 20000 nM
Compound 4 gave a limit, no number; the forecaster's own chance of this, stated with the estimate: 85%; the middle value does not contradict the limit.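

The step from compound 2 to compound 4 cannot be read, because both compounds stand at the same limit: the limit of > 20000 nM in this assay, at which 4 of the 4 values shown sit. Going by these compounds, whether methoxy in place of amino changes inhibition, and how compound 1, compound 2, compound 3 and compound 4 rank against one another, stays open.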